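Swapping sulfamoyl for methanesulfonamido on a 5-lipoxygenase inhibitor

This account rests on a few compounds, and the source may have more. Where it says the series, first, only, none or still open, it means among the compounds named here.

Three compounds share a core in which a hydroxyurea group hangs from a short chain attached to an aromatic ring, and they have been tested in an assay for inhibition of Polyunsaturated fatty acid 5-lipoxygenase (Homo sapiens), read by HPLC, with stated times of 15 min and 10 min; on this read-out higher numbers stand for weaker inhibition and lower numbers for stronger inhibition. Compound 1 `Cc1ccc(C(=O)NCc2ccccc2C(F)(F)F)cc1C#CC(C)N(O)C(N)=O` gives 1700 nM. Compound 2 `C[C@H](C#Cc1cccc(C(=O)NCc2ccccc2C(F)(F)F)c1)N(O)C(N)=O` gives 600 nM. Compound 3 `C[C@H](C#Cc1cccc(C(=O)NCCC(c2ccccc2)c2ccc(S(N)(=O)=O)cc2)c1)N(O)C(N)=O` gives 1000 nM, which is the second highest of the three numbers; its gap to compound 2 and its gap to compound 1 both fall within the usual scatter of this assay, so none of the three can be called clearly stronger or weaker than another.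

The next compound, compound 4 `C[C@H](C#Cc1cccc(C(=O)NCCC(c2ccccc2)c2ccc(NS(C)(=O)=O)cc2)c1)N(O)C(N)=O`, differs from compound 3 in one place: methanesulfonamido in place of sulfamoyl on an aromatic carbon. Within the data shown here, no pair of measured compounds shows what this exchange does. Among the measured compounds shown here, with no such step to lean on, the step from compound 3 to compound 4 is expected to be small, in either direction or none beyond the scatter, as no change at the digits printed from compound 3 to compound 4 (within the scatter) expresses. Compound 4 is therefore estimated at 1000 nM, within a range from 400 nM to 2500 nM.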

Compound 4, half-maximal inhibitory concentration: 900 nM
Estimate against measurement, compound 4: 1.1-fold (0.05 log units) above; the range from low to high includes it.
By their numbers in this assay, from the lowest: compounds 2, 4, 3 and 1 (each within the scatter of the next, the first and the last beyond it).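

In this assay the exchange gives a 1.1-fold lower number from compound 3 to compound 4 (0.05 log units; within the scatter), so at this aromatic carbon, para to a large group, the two groups cannot be told apart. Among these compounds, this is the first measured step at this position, and it shows that methanesulfonamido, which brings one more carbon than sulfamoyl but the same counts of hydrogen-bond donors and acceptors, leaves the number within the scatter. Nothing among the data shown explains this match.

On these data alone, whether an amine, a carboxylic acid or a plain hydrogen on this same aromatic carbon would give a number beyond the scatter remains open. As far as these compounds go, it is also open whether this exchange would read the same way on a different core, or with a longer chain leading to the amide.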